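Chain Terminus Variations on an Isoflavone Aldehyde Dehydrogenase Inhibitor

The source may hold more compounds than are shown below. What is called first, only, known or untested is meant among the compounds shown, and "the series" means these compounds.

Compound 1 `O=c1c(-c2ccc(O)cc2)coc2cc(OCCOCCOCCO)ccc12`: 40 nM
Compound 2 `NCCCCCCOc1ccc2c(=O)c(-c3ccc(O)cc3)coc2c1`: 100 nM
Compound 3 `CCOC(=O)CCCCCOc1ccc2c(=O)c(-c3ccc(O)cc3)coc2c1`: 280 nM

Of the three measured compounds in an assay (Cricetulus griseus) for inhibition of aldehyde dehydrogenase, mitochondrial (Homo sapiens) (on this read-out lower numbers stand for stronger inhibition and higher numbers for weaker inhibition), compound 3 gives the highest number; its nearest neighbour is compound 2, and compound 1 lies furthest from it. The new analogue, compound 4 `O=c1c(-c2ccc(O)cc2)coc2cc(OCCCCCCCCCO)ccc12`, differs from compound 3 by 4-hydroxybutyl in place of ethoxycarbonyl on a saturated chain carbon, five bonds along the chain from an oxygen on an aromatic ring. Among the compounds with values here, two measured steps bear on this change. The step of a 2.8-fold higher number from compound 2 to compound 3 (0.45 log units; beyond the scatter) shows that exchanging the ester terminus for a heteroatom-bearing one lowers the number, and the step of a 7.0-fold higher number from compound 1 to compound 3 (0.85 log units; beyond the scatter) shows the same for a hydroxyl-terminated chain. A hydroxyl terminus is therefore expected to move compound 4 back toward compound 1 in this assay, giving a step of about a 3.1-fold lower number from compound 3 to compound 4 (0.49 log units; beyond the scatter). Compound 4 is estimated at 90 nM, within a range from 35 nM to 250 nM.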

Compound 4, half-maximal inhibitory concentration: 700 nM
For compound 4 the middle estimate is 7.8-fold (0.89 log units) below the measured one; the whole stated range lies below it.
By their numbers in this assay, from the lowest: compound 1; then compound 2; then compound 3; then compound 4.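

In this assay, a hydroxyl end on the saturated chain does not bring the number down: 4-hydroxybutyl in place of ethoxycarbonyl gives a 2.5-fold higher number from compound 3 to compound 4 (0.40 log units; beyond the scatter), and replacing the amino end gives a 7.0-fold higher number from compound 2 to compound 4 (0.85 log units; beyond the scatter). The hydroxyl end alone therefore does not carry the low number of compound 1, since 7-hydroxyheptyl in place of 2-(2-hydroxyethoxy)ethoxy, with a hydroxyl at the end of both chains, gives an 18-fold higher number from compound 1 to compound 4 (1.24 log units; beyond the scatter). Nothing available here explains these steps.

On these data alone, it remains open how a carboxylic acid would behave at the chain end. As far as these compounds go, it is also open whether a shorter saturated chain ending in hydroxyl, or an amine at the end of the chain of compound 1, would lower the number.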